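A few compounds are considered here, and "the series" means these few. Any claim that something is new, unique, unknown or untested is made for them only; others in the source may bear on it.

Measured so far in an assay on SK-N-MC cells for inhibition of Neuropeptide Y receptor type 1 (Homo sapiens); a lower number here means a stronger inhibitor, a higher number a weaker inhibitor:
compound 1 `COC(=O)C1=C(C)N=C(C)/C(=C(/O)OC)C1c1cccc(N/C(=N/CCNC2CCN(c3ccccc3C(F)(F)F)CC2)NC#N)c1` — 14 nM
compound 2 `COC(=O)C1=C(C)N=C(C)/C(=C(/O)OC)C1c1cccc(N/C(=N/CCNC2CCN(c3ccccc3OC(F)(F)F)CC2)NC#N)c1` — 28 nM
compound 3 `COC(=O)C1=C(C)N=C(C)/C(=C(/O)OC)C1c1cccc(NC(=O)NCCNC2CCN(c3ccccc3[N+](=O)[O-])CC2)c1` — 2 nM

Compound 3 gives the lowest number of the three in this assay; compound 1 is nearest to it and compound 2 furthest, both beyond the scatter. Going by the values given here, compound 3 differs from compounds 1 and 2 in two places at once (the urea against the cyanoguanidine, and the group on the aromatic carbon), so their values show only that compound 3 sits well below both.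

Compound 4 `COC(=O)C1=C(C)N=C(C)/C(=C(/O)OC)C1c1cccc(NC(=O)NCCNC2CCN(c3ccccc3C(F)(F)F)CC2)c1` is not yet measured. It keeps the urea of compound 3 and carries trifluoromethyl in place of nitro on an aromatic carbon.

Among the compounds with values here, no measured step shows this exchange directly. Within the data shown here, the only single step in hand, a 2.0-fold higher number from compound 1 to compound 2 (0.30 log units; within the scatter), concerns a different pair of groups at the same place and lies within the scatter, so it gives no direction for compound 4. The gap between compound 3 and compound 1 mixes two changes and cannot be split. The expectation for compound 4 therefore rests mainly on compound 3 (2 nM), with a wide band. Compound 4 is estimated at 5 nM, between 1.5 nM and 18 nM, which is expected to mean a 2.5-fold higher number from compound 3 to compound 4 (0.40 log units; beyond the scatter).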

Compound 4, half-maximal inhibitory concentration: 31 nM
Estimate against measurement, compound 4: 6.2-fold (0.79 log units) below; the measured number lies above the stated range.
By their numbers in this assay, from the lowest: compound 3; then compounds 1, 2 and 4 (each within the scatter of the next, the first and the last beyond it).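

In this assay, with the urea held constant, trifluoromethyl in place of nitro on this aromatic carbon gives a 16-fold higher number from compound 3 to compound 4 (1.19 log units; beyond the scatter), so the number depends strongly on which of these two groups sits at this place. The other step at this place, a 2.0-fold higher number from compound 1 to compound 2 (0.30 log units; within the scatter), lies within the scatter and involves the cyanoguanidine pair, so the step on the urea pair is the only one shown here that goes beyond the scatter, with nitro on the low side. No measurement at hand accounts for the size of this step.

Going by these compounds, whether the exchange keeps this size on the cyanoguanidine remains open. Also open, on these data alone, is where other groups on this aromatic carbon, such as a nitrile, a methoxy group or a carboxylic acid, would fall relative to nitro and trifluoromethyl.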